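This account rests on a few compounds, and the source may have more. Where it says the series, first, only, none or still open, it means among the compounds named here.

Compound 1 `COc1ncc(-c2cc3c(N4CC(C)OC(C)C4)ncnc3s2)cc1NS(=O)(=O)c1ccc(F)cc1F`: 860 nM
Compound 2 `COc1ncc(-c2cc3c(N4CCCC4)ncnc3s2)cc1NS(=O)(=O)c1ccc(F)cc1F`: 2300 nM
Compound 3 `COc1ncc(-c2cc3c(N4CCC(OC)CC4)ncnc3s2)cc1NS(=O)(=O)c1ccc(F)cc1F`: 280 nM

In a functional assay on HGC-27 cells (Homo sapiens) for antiproliferative activity, read by MTT assay, with stated times of 72 h and 4 h (on this read-out higher numbers stand for weaker inhibition and lower numbers for stronger inhibition), compound 3 gives 280 nM, the lowest number of the three and beyond the scatter from both others. Compound 4 `COc1ncc(-c2cc3c(N4CC(OC)C4)ncnc3s2)cc1NS(=O)(=O)c1ccc(F)cc1F` differs from it in one group: 3-methoxyazetidin-1-yl in place of 4-methoxypiperidin-1-yl on an aromatic carbon. Two measured exchanges at this place end at compound 3, a 3.1-fold lower number from compound 1 to compound 3 (0.49 log units; beyond the scatter) and an 8.2-fold lower number from compound 2 to compound 3 (0.91 log units; beyond the scatter). Both went to a lower number, so losing the 4-methoxypiperidin-1-yl is expected to raise it. For the measured compounds named here, the size is uncertain, since no measured compound carries a four-membered ring. A modest rise is expected, estimated as a 2.5-fold higher number from compound 3 to compound 4 (0.40 log units; beyond the scatter). Compound 4 is estimated at 700 nM, with an expected range of 200 nM to 2500 nM.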

Compound 4, half-maximal inhibitory concentration: 830 nM
Compound 4: the middle estimate sits 1.2-fold (0.07 log units) below what was measured, within the range that was stated.
By their numbers in this assay, from the lowest: compound 3; then compounds 4 and 1 (each within the scatter of the next); then compound 2.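

In this assay, moving from the six-membered to the four-membered ring while keeping the methoxy group does not hold the lower number of the 4-methoxypiperidin-1-yl: a 3.0-fold higher number from compound 3 to compound 4 (0.47 log units; beyond the scatter). The 3-methoxyazetidin-1-yl still improves on the pyrrolidin-1-yl, a 2.8-fold lower number from compound 2 to compound 4 (0.44 log units; beyond the scatter), and cannot be told apart from the 2,6-dimethylmorpholin-4-yl, a 1.0-fold lower number from compound 1 to compound 4 (0.02 log units; within the scatter). Nothing available bears on what lies behind these differences.

As far as these compounds go, it remains open how a hydroxy group, an amine or a longer alkoxy chain in place of the methoxy group on these rings would fare at this position.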